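Swapping the basic ring for an oxane in the amide

This account rests on a few compounds, and the source may have more. Where it says the series, first, only, none or still open, it means among the compounds named here.

Compound 2 `CN1CCC(C(=O)N(CC(=O)Nc2cc(F)cc(F)c2)C2CCCCC2)CC1` is the methylated piperidine amide of the shared core, and in an assay on HEK293 cells for inhibition of sodium- and chloride-dependent glycine transporter 1 (Homo sapiens), read by scintillation proximity assay (on this read-out higher numbers stand for weaker inhibition and lower numbers for stronger inhibition), compound 2 gives only a limit, > 25100 nM, not a number. Among the compounds with values here, its one measured neighbour, compound 1 `O=C(CN(C(=O)c1ccc(Cl)cc1)C1CCCCC1)Nc1cc(F)cc(F)c1`, carries a 4-chlorophenyl on the same carbonyl carbon; in this assay compound 1 gives 631 nM, and the step of an at least 39-fold higher number from compound 1 to compound 2 (1.59 log units; beyond the scatter) is the sole measured comparison available, with compound 2 sitting at the limit of > 25100 nM in this assay, at which 1 of the 2 values shown sits. Compound 3 `O=C(CN(C(=O)C1CCOCC1)C1CCCCC1)Nc1cc(F)cc(F)c1` differs from compound 2 by oxan-4-yl in place of 1-methylpiperidin-4-yl on a carbonyl carbon. Within the data shown here, no measured step covers this particular exchange, so the expectation rests on compound 2 alone: a large step from compound 2 remains open in either direction, and a return to a measurable number is expected but uncertain. Compound 3 is expected to give 6000 nM, within a range from 1200 nM to 25100 nM. That estimate corresponds to an expected step of an at least 4.1-fold lower number from compound 2 to compound 3 (0.62 log units; beyond the scatter).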

Compound 3, half-maximal inhibitory concentration: 5010 nM
The estimate for compound 3 lay 1.2-fold (0.08 log units) above the measured number; the measured number falls inside the stated range.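

With oxan-4-yl on the carbonyl carbon, this assay returns a number again, and the exchange for 1-methylpiperidin-4-yl gives an at least 5.0-fold lower number from compound 2 to compound 3 (0.69 log units; beyond the scatter). Compound 2 stands only at a limit of the assay, so this step has a bound and not an exact size: the limit of > 25100 nM in this assay, at which 1 of the 3 values shown sits. A six-membered non-aromatic ring on this carbonyl carbon is thus compatible with a measurable number, yet oxan-4-yl does not match 4-chlorophenyl, as the step of a 7.9-fold higher number from compound 1 to compound 3 (0.90 log units; beyond the scatter) shows.

The compounds shown leave open whether the gap to compound 1 follows from the chlorine or from the ring itself, which an unsubstituted phenyl or a cyclohexyl on the same carbonyl carbon would help to separate. They also do not tell whether the ring nitrogen or its methyl matters in compound 2, a question that the secondary amine piperidin-4-yl would address.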